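A few compounds are considered here, and "the series" means these few. Any claim that something is new, unique, unknown or untested is made for them only; others in the source may bear on it.

Measured so far in a functional assay on M21 cells (Homo sapiens) for antiproliferative activity, read by sulforhodamine B assay, with a stated time of 48 h; a higher number here means a weaker inhibitor, a lower number a stronger inhibitor:
- compound 1 `Cc1cccc(OS(=O)(=O)c2ccc(N3CCN(C)C3=O)cc2)c1` gives 2300 nM
- compound 2 `COc1ccc(OS(=O)(=O)c2ccc(N3CCN(C)C3=O)cc2)cc1` gives only the limit > 100000 nM
- compound 3 `CN1CCN(c2ccc(S(=O)(=O)Oc3ccc(F)cc3)cc2)C1=O` gives only the limit > 100000 nM

Compound 2 stands at the limit (the limit of > 100000 nM in this assay, at which 2 of the 3 values shown sit), so no number is known for it, only that it lies past the range of the readout. From compound 1 the series shows an at least 43-fold higher number from compound 1 to compound 2 (1.63 log units; beyond the scatter) and likewise an at least 43-fold higher number from compound 1 to compound 3 (1.63 log units; beyond the scatter). Between the two limit compounds there is a step that the two limits leave unreadable from compound 2 to compound 3.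

Compound 4 `CCCN1CCN(c2ccc(S(=O)(=O)Oc3ccc(OC)cc3)cc2)C1=O` differs from compound 2 by ethyl in place of hydrogen on a saturated chain carbon bound to an amide-type nitrogen in a ring. For the measured compounds named here, none of the measured steps touches this place: the two readable steps from compound 1 alter the group on the oxygen, and the step between compound 2 and compound 3 cannot be read. Going by the values given here, the series thus gives no direction or size for this change, and the only anchor is compound 2 at the limit. Compound 4 is therefore expected to stay at or near that limit, and the step of a number no higher from compound 2 to compound 4 (the limit leaves the size open) is what this expectation means. The estimate for compound 4 is 100000 nM, within 20000 nM to 300000 nM, most likely reported once more only as a limit.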

Compound 4, half-maximal inhibitory concentration: 23000 nM
For compound 4 the middle estimate is 4.3-fold (0.64 log units) above the measured one; the range from low to high includes it.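

In this assay, for the compounds shown here, the saturated chain carbon bound to an amide-type nitrogen in a ring is the first place where a change is seen to move a compound off the limit: going from methyl to propyl gives an at least 4.3-fold lower number from compound 2 to compound 4 (0.63 log units; beyond the scatter). With 4-methoxyphenyl on the oxygen in both compounds, that group alone does not hold a compound at the limit, and the chain at this place also bears on the read-out. The step sets only a lower bound on the size of the change, and not the size itself, because compound 2 stands at a limit: the limit of > 100000 nM in this assay, at which 2 of the 4 values shown sit.

On these data alone, whether the same change from methyl to propyl would also lower the number with 3-methylphenyl or 4-fluorophenyl on the oxygen remains open. Also open, as far as these compounds go, is how the read-out runs with a longer chain such as butyl or pentyl, or with a chain ending in an amine.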